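The compounds below may be only part of what the source reports. "The series", "measured", "known", "first", "only" and "open" are said of these compounds alone.

Compounds measured in an assay on cell membranes for displacement of a labelled ligand from corticotropin-releasing factor receptor 1 (Rattus norvegicus); a lower number here means a stronger inhibitor, a higher number a weaker inhibitor:
- compound 1 `CCCN(C)c1nc(C)nc2c(-c3c(C)cc(OC)cc3OC)c(C)nn12` gives 6.48 nM
- compound 2 `CCCN(CCC)c1nc(C)nc2c(-c3c(C)cc(OC)cc3OC)c(C)nn12` gives 3.72 nM
- compound 3 `CCCCN(CC)c1nc(C)nc2c(-c3c(C)cc(OC)cc3OC)c(C)nn12` gives 1.72 nM

Compound 3 has the lowest number of the three in this assay; its nearest neighbour is compound 2 (a 2.2-fold lower number from compound 2 to compound 3 (0.34 log units; beyond the scatter)), and the furthest is compound 1 (a 3.8-fold lower number from compound 1 to compound 3 (0.58 log units; beyond the scatter)). The step of a 1.7-fold lower number from compound 1 to compound 2 (0.24 log units; within the scatter) stays within the scatter.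

Compound 4 `CCC(CC)Nc1nc(C)nc2c(-c3c(C)cc(OC)cc3OC)c(C)nn12` is the next compound for this assay. The change from compound 3 is (pentan-3-yl)amino in place of butyl(ethyl)amino on an aromatic carbon; it sits on an aromatic carbon of a six-membered aromatic ring with three nitrogens, between two ring nitrogen atoms, in the shared core.

Going by the values given here, none of the measured steps covers this kind of change: all three measured compounds carry a tertiary amine at that carbon, and the steps among them only rearrange the two chains, with modest effects at most (a 2.2-fold lower number from compound 2 to compound 3 (0.34 log units; beyond the scatter), a 3.8-fold lower number from compound 1 to compound 3 (0.58 log units; beyond the scatter)). Among the compounds with values here, a secondary amine with a hydrogen-bond donor has no precedent in the set, so the direction of the step is uncertain. The working expectation is a modest loss, estimated as a 3.5-fold higher number from compound 3 to compound 4 (0.54 log units; beyond the scatter), with a wide range. Compound 4 is estimated at 6 nM in this assay, within 1.5 nM to 25 nM.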

Compound 4, half-maximal inhibitory concentration: 5 nM
The estimate for compound 4 lay 1.2-fold (0.08 log units) above the measured number; the measured number falls inside the stated range.
By their numbers in this assay, from the lowest: compound 3; then compounds 2, 4 and 1 (each within the scatter of the next).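

In this assay, the (pentan-3-yl)amino group on this aromatic carbon between two ring nitrogen atoms shows that a secondary amine, carrying a hydrogen-bond donor, is tolerated here: the change reads as a 1.3-fold higher number from compound 2 to compound 4 (0.13 log units; within the scatter) and as a 1.3-fold lower number from compound 1 to compound 4 (0.11 log units; within the scatter) against the two tertiary amines, both steps within the scatter. Only butyl(ethyl)amino stands apart from the new group, with a 2.9-fold higher number from compound 3 to compound 4 (0.46 log units; beyond the scatter) as a modest step, so the presence of a hydrogen on this nitrogen does not by itself separate compound 4 from compound 1 or compound 2. No measurement available here accounts for the gap to compound 3.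

On these data alone, the change from compound 3 to compound 4 alters the chains and the hydrogen on the nitrogen together, so the contribution of each remains open. A straight-chain pentylamino group, a cyclopentylamino group or a tertiary ethyl(pentan-3-yl)amino group on the same carbon would help to separate the branched chain from the hydrogen-bond donor.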